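The source may report more compounds than this note shows. Statements on the series, on what has been measured and on what is new or still open speak of the compounds shown alone.

Compound 1 has the structure `CCCS(=O)(=O)Nc1ccc(Cl)c(C(=O)Nc2cnc3[nH]nc(OC)c3c2)c1F`. Among the compounds with values here, in an in vivo ADME assay on the whole organism (strain CD-1) for pharmacokinetics, with Mus musculus as the target (a lower number here means slower removal, a higher number faster removal of the compound), compound 1 gives 1 mL/min/kg, which is the lowest of the two numbers measured so far. Its nearest neighbour is compound 2, with the structure `CCCS(=O)(=O)Nc1ccc(Cl)c(C(=O)Nc2cnc3[nH]ncc3c2)c1F`, which in this assay gives 2.3 mL/min/kg. Within the data shown here, the single measured step between them, a 2.3-fold higher number from compound 1 to compound 2 (0.36 log units; beyond the scatter), comes from a hydrogen in place of methoxy on an aromatic carbon of the shared core.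

Compound 3, with the structure `CCCS(=O)(=O)Nc1ccc(F)c(C(=O)Nc2cnc3[nH]nc(OC)c3c2)c1F`, has not yet been measured. Its difference from compound 1 is fluoro in place of chloro on an aromatic carbon. This change sits on a different part of the core from the change between compound 1 and compound 2, so the measured step does not bear on it directly; nothing measured here speaks to swapping chloro for fluoro. Among the measured compounds shown here, the one exchange of a single small group that was measured moved the clearance only modestly, and so the expectation for compound 3 is a step of about a 1.4-fold higher number from compound 1 to compound 3 (0.15 log units; within the scatter), small and near the scatter, with a slight lean toward a higher number. Compound 3 is therefore estimated at 1.4 mL/min/kg, within a range from 0.6 mL/min/kg to 3.2 mL/min/kg.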

Compound 3, clearance in the Mus musculus assay: 1.3 mL/min/kg
For compound 3 the middle estimate is 1.1-fold (0.03 log units) above the measured one; the measured number falls inside the stated range.
By their numbers in the Mus musculus assay, from the lowest: compounds 1, 3 and 2 (each within the scatter of the next, the first and the last beyond it).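

In the Mus musculus assay, fluoro in place of chloro, at the place ortho to a large group and para to a (propylsulfonyl)amino group, gives a 1.3-fold higher number from compound 1 to compound 3 (0.11 log units; within the scatter), so this read-out does not tell the two compounds apart, and the change brings no measurable shift in how fast the compound is removed. The earlier compounds shown here offered only clearance and a change elsewhere on the core, whereas in a physicochemical assay for solubility, read by HPLC, in phosphate buffer, with a stated time of 24 h, at pH 7.4 (on this read-out higher numbers stand for higher solubility and lower numbers for lower solubility), compound 1 gives 2 ug/mL and compound 3 gives 9 ug/mL. This single exchange of one halogen for another therefore separates the two compounds on solubility even though they cannot be separated on clearance, showing that this place on the ring matters for solubility: the measured solubility of compound 1, 2 ug/mL, and of compound 3, 9 ug/mL, a 4.5-fold higher number (0.65 log units; beyond the scatter)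

All of this rests on one pair of compounds, so it is not yet clear whether the same exchange would act in the same way on the core of compound 2, which lacks the methoxy group. Also open, on these data alone, is how a methyl group or a nitrile at this same place would compare with chloro and fluoro on either read-out.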